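Switching the pyridine substituents on a thiazole acetic acid core

This account rests on a few compounds, and the source may have more. Where it says the series, first, only, none or still open, it means among the compounds named here.

Compound 1 `O=C(O)Cc1sc(C(c2ccc(F)cc2)c2ccc(F)cc2)nc1-c1ccccc1` and compound 2 `Nc1cc(-c2nc(C(c3ccc(F)cc3)c3ccc(F)cc3)sc2CC(=O)O)cc(F)n1` share a core and differ only in the group on one aromatic carbon. In an in vitro functional assay on HEK285-7 cells for antagonist activity at prostaglandin D2 receptor 2 (Homo sapiens), read by BRET and beta-arrestin recruitment (a lower number here means a stronger inhibitor, a higher number a weaker inhibitor), compound 1 gives 240 nM, while compound 2 gives 1400 nM. This is the higher of the two numbers, and the step of a 5.8-fold higher number from compound 1 to compound 2 (0.77 log units; beyond the scatter) shows that placing the 2-amino-6-fluoropyridin-4-yl group there weakened inhibition beyond the usual scatter.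

Going by the values given here, compound 3 `CN(C)c1cc(-c2nc(C(c3ccc(F)cc3)c3ccc(F)cc3)sc2CC(=O)O)ccn1` keeps the core of compound 2 and changes only this group: 2-(dimethylamino)pyridin-4-yl in place of 2-amino-6-fluoropyridin-4-yl on an aromatic carbon. Among the compounds with values here, no measured step bears directly on this exchange. Within the data shown here, the only step known, from phenyl to the aminofluoropyridinyl group, weakened inhibition; compound 3 keeps a pyridine ring but carries a dimethylamino group and no fluorine, so it stands between the two measured cases in character. The step of a 1.4-fold lower number from compound 2 to compound 3 (0.15 log units; within the scatter) is therefore expected to stay within or close to the scatter, with a slight lean toward a lower number. Compound 3 is estimated at 1000 nM in this assay, with a likely range from 300 nM to 3500 nM.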

Compound 3, half-maximal inhibitory concentration: > 100000 nM
Compound 3 ended at the assay's limit; the forecaster's own chance of this, stated with the estimate: 3%; at least 100-fold (2.00 log units) between middle value and limit.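

Compound 3 stands at a limit of this assay, not at a true number: the limit of > 100000 nM in this assay, at which 1 of the 3 values shown sits. The position on the shared core that carries these rings is therefore far less forgiving than the first pair showed, with 2-(dimethylamino)pyridin-4-yl in place of 2-amino-6-fluoropyridin-4-yl giving an at least 71-fold higher number from compound 2 to compound 3 (1.85 log units; beyond the scatter), and the same group in place of phenyl giving an at least 410-fold higher number from compound 1 to compound 3 (2.61 log units; beyond the scatter). Compounds 2 and 3 both carry a six-membered aromatic ring with one hetero atom and no net charge, so at this position the outcome depends heavily on what is attached to that ring, not only on the presence of the ring itself.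

Which part of the exchange matters remains open, as the amino group, the fluorine and the dimethylamino group all change in a single step, and the loss of the hydrogen-bond donor cannot be separated from the other changes. A methylamino group or a methoxy group on the same pyridine ring, or an unsubstituted pyridin-4-yl ring, could help tell these contributions apart.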